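The compounds below may be only part of what the source reports. "The series", "measured", "known", "first", "only" and "open" are said of these compounds alone.

Working notes on the series. In an ADME assay on HepG2 2.2.15 cells (Homo sapiens) for cytotoxicity (on this read-out lower numbers stand for higher toxicity in this test and higher numbers for lower toxicity in this test), compound 1 `O=c1[nH]c2ccc(Cl)cc2c(-c2ccccc2Cl)c1CCO` gives 388000 nM. For compound 2 `ClCCc1c(Cl)nc2ccc(Cl)cc2c1-c1ccccc1Cl` this assay records only a limit, > 1400000 nM. Compound 3 `CC(=O)OCCc1c(Cl)nc2ccc(Cl)cc2c1-c1ccccc1Cl` gives 116000 nM in this assay, the lowest of the two numbers; compound 1 is the nearest, with a higher number beyond the scatter. Compound 4 `OCCc1c(Cl)nc2ccc(Cl)cc2c1-c1ccccc1Cl` is not yet measured; it differs from compound 3 by hydrogen in place of acetyl on an oxygen on a saturated carbon. For the measured compounds named here, the only measured step, an at least 12-fold lower number from compound 2 to compound 3 (1.08 log units; beyond the scatter), concerns a different change at the same chain end, and one value sits at the limit of > 1400000 nM in this assay, at which 1 of the 3 values shown sits, so no step bears directly on removal of the acetyl. Compound 1, bearing the same hydroxyethyl chain on a different core, gives a higher number than compound 3. For compound 4 the estimate is 250000 nM, with a range from 100000 nM to 700000 nM. The expected step is therefore a 2.2-fold higher number from compound 3 to compound 4 (0.33 log units; beyond the scatter), a higher number but of uncertain size.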

Compound 4, half-maximal cytotoxic concentration: 42500 nM
Estimate against measurement, compound 4: 5.9-fold (0.77 log units) above, outside the stated range (below it).
By their numbers in this assay, from the lowest: compound 4; then compound 3; then compound 1. At a limit, above all of these: compound 2.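

In this assay, 2-hydroxyethyl in place of 2-acetoxyethyl gives a 2.7-fold lower number from compound 3 to compound 4 (0.44 log units; beyond the scatter), so the acetyl is not needed for a low number on the shared core. Chloro at this chain end stands apart from hydroxy, with an at least 32-fold lower number from compound 2 to compound 4 (1.51 log units; beyond the scatter), and the size of that step stays open-ended, since compound 2 is recorded only as a limit: the limit of > 1400000 nM in this assay, at which 1 of the 4 values shown sits.

On these data alone, how an amine or a carboxylic acid at this chain end would read remains open, as does a longer chain carrying the hydroxy.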